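This account rests on a few compounds, and the source may have more. Where it says the series, first, only, none or still open, it means among the compounds named here.

Working notes on the series. In a functional assay on MCF7 cells (Homo sapiens) for inhibition, read by resazurin assay, with a stated time of 24 h (a lower number here means a stronger inhibitor, a higher number a weaker inhibitor), compound 1 `O=C1Nc2c(C(F)(F)F)cccc2C1(c1ccc(O)cc1)c1ccc(OC(F)(F)F)cc1` gives 20 nM and compound 3 `O=C1Nc2c(C(F)(F)F)cccc2C1(c1ccc(OC(F)(F)F)cc1)c1ccc(O)c(F)c1` gives 33 nM. Fluoro in place of hydrogen on an aromatic carbon accounts for a 1.7-fold higher number from compound 1 to compound 3 (0.22 log units; within the scatter), so compound 3 stands level with compound 1 within the scatter. Compound 2 `O=C1Nc2c(C(F)(F)F)cccc2[C@@]1(c1ccc(O)cc1)C1CCC(F)(F)CC1` reads > 1000 nM, which is a limit of the assay and not a number.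

The next step leads to compound 4 `O=C1Nc2c(C(F)(F)F)cccc2C1(c1ccc(OC(F)(F)F)cc1)c1ccc(OC(F)(F)F)cc1`: 4-(trifluoromethoxy)phenyl in place of 3-fluoro-4-hydroxyphenyl on a saturated ring carbon. In words, 4-(trifluoromethoxy)phenyl comes in place of 3-fluoro-4-hydroxyphenyl on a saturated ring carbon. For the measured compounds named here, the only measured step touching the leaving group is a 1.7-fold higher number from compound 1 to compound 3 (0.22 log units; within the scatter), a small edit that stays within the scatter and says little about replacing the whole group. Going by the values given here, no measured compound lacks the hydroxy group. The nearest guide is compound 2 at > 1000 nM, again a limit, where a different group stands on that saturated ring carbon. A large move in this assay towards a weaker inhibitor is therefore expected. The estimated step is a 45-fold higher number from compound 3 to compound 4 (1.66 log units; beyond the scatter), beyond the scatter, and the assay may well report only a limit. For compound 4 the estimate is 1500 nM, with an expected range of 250 nM to 8000 nM.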

Compound 4, half-maximal inhibitory concentration: > 1000 nM
Compound 4: a limit, no number (the forecaster's own chance of this, stated with the estimate: 60%); the middle value is on the limit's open side.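

In this assay, the hydroxy group of compound 1 cannot be capped on its oxygen without a large loss: the step is an at least 50-fold higher number from compound 1 to compound 4 (1.69 log units; beyond the scatter). For the compounds shown here, replacing the whole 3-fluoro-4-hydroxyphenyl group gives the same picture, with an at least 30-fold higher number from compound 3 to compound 4 (1.48 log units; beyond the scatter), whereas the only earlier step on this aryl group, a 1.7-fold higher number from compound 1 to compound 3 (0.22 log units; within the scatter), stayed within the scatter, so this position tolerates fluoro on the aromatic ring but not the exchange of hydroxy for trifluoromethoxy. Both new steps give only a minimum size, because compound 4 stands at a limit of the assay and not at a number: the limit of > 1000 nM in this assay, at which 2 of the 4 values shown sit.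

The compounds shown do not separate the loss of the hydrogen on that oxygen from the arrival of the trifluoromethyl group, and a methyl ether or an amine in place of the hydroxy group would bear directly on that question. Going by these compounds, how far compound 4 lies beyond its limit also stays open, so the true size of both steps is unknown.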